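A few compounds are considered here, and "the series" means these few. Any claim that something is new, unique, unknown or untested is made for them only; others in the source may bear on it.

The measured compounds:

- compound 1, `Nc1ccccc1NC(=O)CCCCCCc1nc(-c2ccccc2)no1`: > 10000 nM
- compound 2, `Nc1ccccc1NC(=O)CCCCCCc1nc(-c2ccc([N+](=O)[O-])cc2)no1`: > 10000 nM
- compound 3, `O=C(CCCCCCc1nc(-c2ccccc2)no1)C(F)(F)F`: 760 nM

All three were tested in an assay on isolated protein for inhibition of histone deacetylase 8 (Homo sapiens), read by fluorescence, with a stated time of 10 min; a higher number here means a weaker inhibitor, a lower number a stronger inhibitor. Compound 1 gives > 10000 nM in this assay, which is a limit of the assay and not a number. Compound 2 likewise gives > 10000 nM in this assay, again a limit. Among the compounds with values here, compound 3 gives 760 nM in this assay, the only real number among the three.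

The two cores differ by trifluoromethyl in place of (2-aminophenyl)amino on a carbonyl carbon, a change that makes an at least 13-fold lower number from compound 1 to compound 3 (1.11 log units; beyond the scatter). The change from compound 1 to compound 2 is nitro in place of hydrogen on an aromatic carbon; its step, a step that the two limits leave unreadable from compound 1 to compound 2, cannot be sized because both compounds sit at the limit of > 10000 nM in this assay, at which 2 of the 3 values shown sit.

Compound 4, `O=C(CCCCCCc1nc(-c2cccc([N+](=O)[O-])c2)no1)C(F)(F)F`, has not yet been measured in this assay. It differs from compound 3 by nitro in place of hydrogen on an aromatic carbon. This is the same kind of change as from compound 1 to compound 2, but not the same: there the nitro group sits para to a large group, here meta to a large group. The earlier step of this kind gives no readable size, so there is nothing measured to carry over. Compound 4 is expected to give about 700 nM in this assay, most likely between 250 nM and 2500 nM. The expected step is a 1.1-fold lower number from compound 3 to compound 4 (0.04 log units; within the scatter), resting on compound 3 at 760 nM as the only anchor and on the unreadable size of a step that the two limits leave unreadable from compound 1 to compound 2.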

Compound 4, half-maximal inhibitory concentration: 830 nM
For compound 4 the middle estimate is 1.2-fold (0.07 log units) below the measured one, and the stated range covers the measured number.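

In this assay, placing a nitro group on the aromatic ring of compound 3 gives a 1.1-fold higher number from compound 3 to compound 4 (0.04 log units; within the scatter), so on this core the change leaves no mark that can be told apart from ordinary repeat-to-repeat variation. The same kind of change on the core of compound 1 cannot be read, because compound 1 and compound 2 both give a limit of the assay and not a number: the limit of > 10000 nM in this assay, at which 2 of the 4 values shown sit. The series therefore offers a single readable step, on a single core and with the nitro group meta to a large group, while compound 2 carries it at a different place on the ring; this does not show that the result carries over to the core of compound 1, or that a nitro group makes no difference wherever it sits.

The compounds shown leave open how the core of compound 3 would respond to a nitro group at another place on the ring, or to an amine or a carboxylic acid at the same place. Within the data shown here, they also leave open whether a longer chain in place of the one shared by compound 3 and compound 4 would move the number in this assay.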